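The source may hold more compounds than are shown below. What is called first, only, known or untested is meant among the compounds shown, and "the series" means these compounds.

Compound 1 `CNC(=O)/C=C/CNCCOc1ccc(Oc2c(-c3ccc(F)cc3)sc3cc(O)ccc23)cc1` gives 16100 nM as measured.
Compound 2 `CN(C)C(=O)/C=C/CNCCOc1ccc(Oc2c(-c3ccc(F)cc3)sc3cc(O)ccc23)cc1` gives 13800 nM as measured.
Compound 3 `C=CC(=O)N1CC(Oc2ccc(Oc3c(-c4ccc(F)cc4)sc4cc(O)ccc34)cc2)C1` gives 23500 nM as measured.

In a functional assay on MCF7 cells (Homo sapiens) for antiproliferative activity, read by CCK-8 assay, with a stated time of 48 h (on this read-out higher numbers stand for weaker inhibition and lower numbers for stronger inhibition), compound 2 at 13800 nM lies within the scatter of both other compounds, so the three cannot be ranked. Among the compounds with values here, compound 4 `O=C(/C=C/CNCCOc1ccc(Oc2c(-c3ccc(F)cc3)sc3cc(O)ccc23)cc1)N1CCCCC1` has piperidin-1-yl in place of dimethylamino on a carbonyl carbon, the change piperidin-1-yl in place of dimethylamino on a carbonyl carbon being its only difference from compound 2. Within the data shown here, two measured steps bear on it. Methyl in place of hydrogen on an amide-type nitrogen gave a 1.2-fold lower number from compound 1 to compound 2 (0.07 log units; within the scatter) and replacing the whole chain with 1-(vinylcarbonyl)azetidin-3-yl gave a 1.7-fold higher number from compound 2 to compound 3 (0.23 log units; within the scatter) while no measured compound carries this ring on the carbonyl. With both steps within the scatter, no step beyond it is expected in this assay here. The expected step is a 1.2-fold lower number from compound 2 to compound 4 (0.06 log units; within the scatter) on this estimate. For compound 4 the estimated value is 12000 nM with an expected range from 6000 nM to 24000 nM in this read-out.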

Compound 4, half-maximal inhibitory concentration: 16400 nM
The estimate for compound 4 lay 1.4-fold (0.14 log units) below the measured number, within the range that was stated.
By their numbers in this assay, from the lowest: compounds 2, 1, 4 and 3 (each within the scatter of the next).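

In this assay, piperidin-1-yl in place of dimethylamino on the carbonyl carbon gave a 1.2-fold higher number from compound 2 to compound 4 (0.07 log units; within the scatter), and piperidin-1-yl in place of methylamino gave a 1.0-fold higher number from compound 1 to compound 4 (0.01 log units; within the scatter). The earlier compounds had shown this position only with methylamino and dimethylamino, and it now also takes a six-membered non-aromatic ring with no step beyond the scatter. Nothing at hand explains this result. The compounds shown leave open whether morpholin-4-yl or piperazin-1-yl on this carbonyl carbon would give a step beyond the scatter. They also leave open what a carboxylic acid on the piperidine ring would do.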